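Replacing a hydroxyl with a methyl on the cyclohexyl amide

This account rests on a few compounds, and the source may have more. Where it says the series, first, only, none or still open, it means among the compounds named here.

Measured so far in an ADME assay on MRC5 cells (Homo sapiens) for inhibition, with a stated time of 72 h; on this read-out higher numbers stand for an effect only at larger amounts of compound and lower numbers for an effect already at smaller amounts:
Compound 1 `CO[C@H]1CC[C@H](NC(=O)c2n[nH]cc2NC(=O)c2ccc(N3CCCC3)cc2)CC1` gives > 50000 nM.
Compound 2 `COc1cccc(OC)c1C(=O)Nc1c[nH]nc1C(=O)N[C@H]1CC[C@H](O)CC1` gives 34000 nM.
Compound 3 `CO[C@H]1CC[C@H](NC(=O)c2n[nH]cc2NC(=O)c2c(C)nc3ccccn23)CC1` gives 34000 nM.

The value for compound 1 is a limit of the assay rather than a number, as recorded in the limit of > 50000 nM in this assay, at which 1 of the 3 values shown sits. Compound 2 stands level with compound 3 at the digits shown; the two values lie within the usual scatter of repeated measurements, so no order between them can be read. Compound 2 is therefore one of two compounds whose effect in this assay is seen at a similar amount, while the third compound gave only a limit.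

Compound 4 `COc1cccc(OC)c1C(=O)Nc1c[nH]nc1C(=O)NC1CCC(C)CC1` has not yet been measured in this assay. It differs from compound 2 in a single place: 4-methylcyclohexyl in place of 4-hydroxycyclohexyl on an amide-type nitrogen. For the measured compounds named here, no step between two measured compounds carries this same change, so its size cannot be read from the numbers already in hand; all that the measured set shows is that the three compounds sit at the weak end of the scale.

Compound 4 is expected to stay near compound 2, with a modest step of a 1.7-fold lower number from compound 2 to compound 4 (0.23 log units; within the scatter) that may not exceed the scatter. Compound 4 is estimated at 20000 nM, within a range from 7000 nM to 50000 nM.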

Compound 4, half-maximal effective concentration: 45000 nM
Estimate against measurement, compound 4: 2.3-fold (0.35 log units) below; the range from low to high includes it.
By their numbers in this assay, from the lowest: compounds 2, 3 and 4 (each within the scatter of the next). At a limit, above all of these: compound 1.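

In this assay, the change to 4-methylcyclohexyl in place of 4-hydroxycyclohexyl on an amide-type nitrogen gives a 1.3-fold higher number from compound 2 to compound 4 (0.12 log units; within the scatter). This is the only step shown that changes a single place, and it gives the first direct view of this position: the hydrogen-bond donor and acceptor counted on 4-hydroxycyclohexyl are gone, yet the read-out shows no change that can be told from scatter, so the hydroxyl is not needed for the effect seen in compound 2. Only compound 1 stands at a limit of the assay rather than at a number: the limit of > 50000 nM in this assay, at which 1 of the 4 values shown sits.

As far as these compounds go, what an amine or a carboxylic acid would do at the same place on the cyclohexyl ring remains open, as does the outcome of a longer chain there. From the compounds shown here alone, it is also open whether the same change would give a similar result with the other amide groups of compound 1 and compound 3, and whether it would matter in a compound with an effect at much smaller amounts.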